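Amide nitrogen substituents on a shared tetrazole-bearing core

The source may report more compounds than this note shows. Statements on the series, on what has been measured and on what is new or still open speak of the compounds shown alone.

The three measured compounds share one core and differ only in the group on an amide-type nitrogen. Compound 1 `CCOC(=O)CNC(=O)c1cccc2nc(OCC)n(Cc3ccc(-c4ccccc4-c4nnn[nH]4)cc3)c12` carries (ethoxycarbonyl)methyl there and in an assay on isolated protein for inhibition of NEDD8-activating enzyme E1 regulatory subunit (Homo sapiens), read by Western blot, with stated times of 10 min and 30 min, tested at 25 uM (a higher number here means more inhibition at the concentration tested (going by the name of the read-out), a lower number less inhibition), compound 1 gives 46.5%. Compound 2 `CCOc1nc2cccc(C(=O)Nc3ccc(F)cc3)c2n1Cc1ccc(-c2ccccc2-c2nnn[nH]2)cc1` carries 4-fluorophenyl; in this assay compound 2 gives 45.3%, with a number 1.2 percentage points lower from compound 1 to compound 2 (within the scatter). Compound 3 `CCOc1nc2cccc(C(=O)Nc3ccc(OC)cc3)c2n1Cc1ccc(-c2ccccc2-c2nnn[nH]2)cc1` carries 4-methoxyphenyl; in this assay compound 3 gives 25.8%, the lowest of the three numbers, with a number 20.7 percentage points lower from compound 1 to compound 3 (beyond the scatter) and a number 19.5 percentage points lower from compound 2 to compound 3 (beyond the scatter).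

Compound 4 `CCOc1nc2cccc(C(=O)NCc3ccco3)c2n1Cc1ccc(-c2ccccc2-c2nnn[nH]2)cc1` differs from compound 3 by (furan-2-yl)methyl in place of 4-methoxyphenyl on an amide-type nitrogen. Within the data shown here, both measured steps into compound 3 lowered the number, so leaving 4-methoxyphenyl is the part that bears here; no measured pair shows (furan-2-yl)methyl itself. Among the measured compounds shown here, compound 1 is the only other compound whose substituent on this nitrogen is methyl-linked and it stands higher because of 46.5%, so a step upward, back toward that level, is expected but with wide uncertainty. The expected step is a number 14.2 percentage points higher from compound 3 to compound 4 (beyond the scatter). Compound 4 is therefore estimated at 40%, within 25% to 55%.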

Compound 4, a percentage reported as inhibition, at one concentration (the size of the read-out at that concentration, not a potency): 37.5%
For compound 4 the middle estimate is 2.5 percentage points above the measured one; measured number inside the range.
By their numbers in this assay, from the lowest: compound 3; then compounds 4, 2 and 1 (each within the scatter of the next).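

In this assay there is a number 11.7 percentage points higher from compound 3 to compound 4 (beyond the scatter) for (furan-2-yl)methyl in place of 4-methoxyphenyl, while there is a number 7.8 percentage points lower from compound 2 to compound 4 (within the scatter) for the swap from 4-fluorophenyl and a number 9 percentage points lower from compound 1 to compound 4 (within the scatter) for the swap of ethoxycarbonyl on the chain carbon. This position thus accepts a five-membered aromatic ring on a methyl link with no step beyond the scatter from 4-fluorophenyl or the ethoxycarbonyl chain, and among the four substituents only 4-methoxyphenyl stands apart, at the low end. Nothing else measured explains this grouping.

As far as these compounds go, what a plain benzyl group, a morpholine ring or a carboxylic acid on this nitrogen would give remains open. Also open, from the compounds shown here alone, is whether 4-chlorophenyl or 4-hydroxyphenyl would stay with 4-fluorophenyl or fall with 4-methoxyphenyl.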